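Bromo to nitro on a shared core

The source may report more compounds than this note shows. Statements on the series, on what has been measured and on what is new or still open speak of the compounds shown alone.

Values so far in a functional assay on HepG2 cells (Homo sapiens) for antiproliferative activity, read by fluorescence and resazurin assay, with a stated time of 48 h; a lower number here means a stronger inhibitor, a higher number a weaker inhibitor

Compound 1 `CCOc1ccc2nc(Cl)c(/C=N/NC(=O)c3cc4cc([N+](=O)[O-])ccc4oc3=O)cc2c1` gives 18100 nM
Compound 2 `O=C(N/N=C/c1cc2ccccc2nc1Cl)c1cc2cc(Br)ccc2oc1=O` gives 9420 nM

Compound 2 at 9420 nM and compound 1 at 18100 nM lie within the usual scatter of each other, so the two cannot be ranked on these numbers.

The unmeasured compound is compound 3 `O=C(N/N=C/c1cc2ccccc2nc1Cl)c1cc2cc([N+](=O)[O-])ccc2oc1=O` and it differs from compound 2 in one place: nitro in place of bromo on an aromatic carbon of a six-membered aromatic ring of carbon only, part of a fused or bridged system of two rings (nitro in place of bromo on an aromatic carbon).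

Among the measured compounds shown here, no two measured compounds differ in one place only, so the data hold no direct measure of this change. For the measured compounds named here, the only guide is the narrow spread of the two values, and no step beyond the scatter is expected in this assay for this change. The estimated change is a 1.3-fold higher number from compound 2 to compound 3 (0.11 log units; within the scatter) and it is expected to stay within the scatter, with no firm direction. For compound 3 the expected value is 12000 nM with an estimated range from 5000 nM to 30000 nM.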

Compound 3, half-maximal inhibitory concentration: 22800 nM
The estimate for compound 3 lay 1.9-fold (0.28 log units) below the measured number; low and high end bracket the measured number.
By their numbers in this assay, from the lowest: compounds 2, 1 and 3 (each within the scatter of the next, the first and the last beyond it).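

In this assay, nitro in place of bromo on this aromatic carbon gives a 2.4-fold higher number from compound 2 to compound 3 (0.38 log units; beyond the scatter), a modest step and the first direct measure of this change in the series. With the rest of the molecule held constant, the bromo compound therefore has the lower number, so the group at this position can shift the value, if only slightly. Hydrogen in place of ethoxy on an aromatic carbon, with the nitro group kept, gives a 1.3-fold higher number from compound 1 to compound 3 (0.10 log units; within the scatter), so in this nitro pair that change cannot be told apart from repeat scatter. No measurement at hand bears on the reason for either result.

The compounds shown compare only bromo and nitro at this position, so they leave open how an amine, a carboxylic acid or a methoxy group there would read in this assay, and whether the modest step is part of any wider trend. Also open, on these data alone, is whether the exchange of ethoxy for hydrogen would stay as small with bromo in place of nitro on the shared core.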